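The compounds below may be only part of what the source reports. "The series", "measured", "known", "first", "only" and "open" are said of these compounds alone.

Compound 1 `CCOC(=O)N1CCC(NS(=O)(=O)c2ccc(NC(=O)c3ccccc3)c3ccccc23)CC1` gives 0.17 nM in an assay on L1.2 cells for binding affinity to C-C chemokine receptor type 8 (Homo sapiens); on this read-out lower numbers stand for stronger inhibition and higher numbers for weaker inhibition. Compound 2 `CCOC(=O)N1CCC(NS(=O)(=O)c2ccc(O)c3ccccc23)CC1` reaches only the limit of this assay, > 5000 nM. Compound 2 thus sits at the limit of > 5000 nM in this assay, at which 1 of the 2 values shown sits. Going by the values given here, the only measured step that bears on the change is an at least 29000-fold higher number from compound 1 to compound 2 (4.46 log units; beyond the scatter), a large loss on replacing benzamido with hydroxy. Compound 3 `CCOC(=O)N1CCC(NS(=O)(=O)c2ccc(NC(=O)N3CCCCC3)c3ccccc23)CC1` differs from compound 2 by ((piperidin-1-yl)carbonyl)amino in place of hydroxy on an aromatic carbon, which, like the benzamido of compound 1, returns a carbonyl-bearing nitrogen to the aromatic carbon. A large gain is therefore expected, an at least 5000-fold lower number from compound 2 to compound 3 (3.69 log units; beyond the scatter), in this assay. Compound 3 is estimated at 1 nM, with a range from 0.1 nM to 20 nM.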

Compound 3, inhibition constant: 126 nM
Beside the measured number, compound 3's estimate is 130-fold (2.10 log units) below it; the measured number lies above the stated range.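

With ((piperidin-1-yl)carbonyl)amino at this position, this assay shows an at least 39-fold lower number from compound 2 to compound 3 (1.59 log units; beyond the scatter), so a carbonyl-bearing nitrogen recovers part of the inhibition lost with hydroxy. For compound 2, > 5000 nM is a limit of the assay, so that step is a bound only. The carbonyl-bearing nitrogen alone does not restore the level of compound 1: the group on the carbonyl carbon also counts, with a 740-fold higher number from compound 1 to compound 3 (2.87 log units; beyond the scatter).

Still open, going by these compounds, is whether the ring's lack of aromaticity or the nitrogen on the carbonyl carbon drives that loss. Cyclohexyl or anilino on the carbonyl carbon would separate the two.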